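The compounds below may be only part of what the source reports. "The series", "measured", "known", "first", "only" and "open" are said of these compounds alone.

Measured in a functional assay on MGC-803 cells (Homo sapiens) for antiproliferative activity, read by MTT assay, with a stated time of 72 h; on this read-out higher numbers stand for weaker inhibition and lower numbers for stronger inhibition:

- Compound 1 `C/C(=N\NC(=O)c1cccc(S(=O)(=O)N2CCOCC2)c1)c1cccc(O)c1`: > 100000 nM (a limit)
- Compound 2 `C/C(=N\NC(=O)c1cccc(S(=O)(=O)N2CCOCC2)c1)c1cc(F)ccc1O`: 2260 nM
- Compound 3 `O=C(N/N=C/c1ccco1)c1cccc(S(=O)(=O)N2CCOCC2)c1`: > 100000 nM (a limit)

Compound 3 gives no number, only a limit, and sits at the limit of > 100000 nM in this assay, at which 2 of the 3 values shown sit. Compound 4 `O=C(N/N=C/c1ccccn1)c1cccc(S(=O)(=O)N2CCOCC2)c1` carries pyridin-2-yl in place of furan-2-yl on a carbon with a double bond to nitrogen. Among the measured compounds shown here, the one measured step at such a carbon is an at least 44-fold lower number from compound 1 to compound 2 (1.64 log units; beyond the scatter), a large change, but it exchanged 3-hydroxyphenyl for 5-fluoro-2-hydroxyphenyl, a different pair of groups. It shows only that this place can matter, so a much smaller move towards a lower number is expected in this assay, and a second limit remains quite possible. The expected size is an at least 3.3-fold lower number from compound 3 to compound 4 (0.52 log units; beyond the scatter). For compound 4 the estimate is 30000 nM, with an expected range from 3000 nM to 150000 nM.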

Compound 4, half-maximal inhibitory concentration: 81700 nM
Beside the measured number, compound 4's estimate is 2.7-fold (0.44 log units) below it, and the stated range covers the measured number.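

In this assay the exchange of furan-2-yl for pyridin-2-yl gives an at least 1.2-fold lower number from compound 3 to compound 4 (0.08 log units; that floor lies within the scatter) and so yields a measured number where furan-2-yl gave only a limit. The floor of this step lies within the scatter, so the data do not establish a gain of any real size at this carbon. Compound 3 remains a limit: the limit of > 100000 nM in this assay, at which 2 of the 4 values shown sit.

Going by these compounds, how large the step truly is stays open, since compound 3 has no number. Also open, on these data alone, is what an amine or a carboxylic acid on the pyridin-2-yl ring would do.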